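A few compounds are considered here, and "the series" means these few. Any claim that something is new, unique, unknown or untested is made for them only; others in the source may bear on it.

Measured in a functional assay on B16 cells (Mus musculus) for inhibition; a lower number here means a stronger inhibitor, a higher number a weaker inhibitor:

- compound 1 `Cc1ccc(/C=N/NC(N)=S)cc1`: 6800 nM
- compound 2 `CC(C)(C)c1ccc(/C=N/NC(N)=S)cc1`: 2700 nM
- compound 3 `Cc1ccccc1/C=N/NC(N)=S`: 3400 nM

Compound 3, at 3400 nM, lies within the usual scatter of both compound 1 and compound 2, so it cannot be told apart from either. Those two are separated from each other by a modest step. The next compound, compound 4 `COc1ccccc1/C=N/NC(N)=S`, has methoxy in place of methyl on an aromatic carbon.

Within the data shown here, only one measured step bears on this change: a 2.5-fold lower number from compound 1 to compound 2 (0.40 log units; beyond the scatter). That step also replaces a methyl group on an aromatic carbon, but with tert-butyl, and it was modest. Among the measured compounds shown here, no measured compound carries methoxy, so the evidence is indirect. For the measured compounds named here, with so small a change seen in the one comparison available, no step beyond the scatter is expected in this assay, and the direction stays open. The expected change is a 1.1-fold lower number from compound 3 to compound 4 (0.05 log units; within the scatter). For compound 4 the estimated value is 3000 nM, with an expected range from 1300 nM to 7000 nM.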

Compound 4, half-maximal inhibitory concentration: 16100 nM
For compound 4 the middle estimate is 5.4-fold (0.73 log units) below the measured one, outside the stated range (above it).
By their numbers in this assay, from the lowest: compounds 2, 3 and 1 (each within the scatter of the next, the first and the last beyond it); then compound 4.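

In this assay, the aromatic carbon ortho to a group of 6 heavy atoms turns out to be sensitive to what it carries: swapping methyl for methoxy gives a 4.7-fold higher number from compound 3 to compound 4 (0.68 log units; beyond the scatter) and makes compound 4 a weaker inhibitor. Among these compounds, the only earlier step that replaced a methyl group, a 2.5-fold lower number from compound 1 to compound 2 (0.40 log units; beyond the scatter), went the other way, so changing this group does not move the number in one fixed direction, although that step brought in tert-butyl at another ring carbon. Nothing available gives the reason for the shift seen with methoxy.

Going by these compounds, whether a hydroxyl group, an amine or ethoxy at this same carbon would fall nearer compound 3 or nearer compound 4 remains open. On these data alone, it is also open whether methoxy on the ring carbon that carries methyl in compound 1 would change the number as much.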